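Swapping the distal aryl ring in an agonist series

This account rests on a few compounds, and the source may have more. Where it says the series, first, only, none or still open, it means among the compounds named here.

Measured compounds:
compound 1 `CCc1ccccc1-c1cccc(COc2ccc([C@H](CC(=O)O)c3nccn3C)cc2)c1` gives 65000 nM in an assay on CHO cells for agonist activity at Free fatty acid receptor 1 (Homo sapiens), read by luminescence, with a stated time of 20 s, in the presence of a further agent that is not named here; on this read-out lower numbers stand for an effect already at smaller amounts and higher numbers for an effect only at larger amounts of compound
compound 2 `Cc1c(Cl)cccc1-c1cccc(COc2ccc([C@H](CC(=O)O)c3nccn3C)cc2)c1` gives 22000 nM in this assay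
compound 3 `Cc1cc(Cl)ccc1-c1cc(COc2ccc([C@H](CC(=O)O)c3nccn3C)cc2)ccc1C` gives 9800 nM in this assay

Compound 2 holds the second highest of the three numbers; compound 3 shows a lower value and compound 1 a higher one. The change to the unmeasured compound 4 `Cn1ccnc1[C@@H](CC(=O)O)c1ccc(OCc2cccc(-c3ccccc3Cl)c2)cc1` is 2-chlorophenyl in place of 3-chloro-2-methylphenyl on an aromatic carbon. Among the compounds with values here, the one measured step at that same position, a 3.0-fold lower number from compound 1 to compound 2 (0.47 log units; beyond the scatter), was modest. Since compound 4 drops both the methyl and shifts to a smaller chlorophenyl, the outcome is uncertain, and a step within or only slightly beyond the scatter is expected, a 1.4-fold higher number from compound 2 to compound 4 (0.13 log units; within the scatter). Compound 4 is therefore estimated at 30000 nM, with a range from 10000 nM to 90000 nM.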

Compound 4, half-maximal effective concentration: 56000 nM
Compound 4: the middle estimate sits 1.9-fold (0.27 log units) below what was measured, within the range that was stated.
By their numbers in this assay, from the lowest: compound 3; then compound 2; then compounds 4 and 1 (each within the scatter of the next).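

In this assay, 2-chlorophenyl in place of 3-chloro-2-methylphenyl gave (a 2.5-fold higher number from compound 2 to compound 4 (0.41 log units; beyond the scatter)), so a chlorine on this ring does not by itself keep the lower number of compound 2. Chloro in place of ethyl gave (a 1.2-fold lower number from compound 1 to compound 4 (0.06 log units; within the scatter)), so 2-chlorophenyl and 2-ethylphenyl cannot be told apart at this place. No measured evidence accounts for these results.

On these data alone, it remains open whether the lower number of compound 2 depends on the chloro and methyl groups together. As far as these compounds go, how a 2-methylphenyl or a 2-methoxyphenyl group would read at this place also stays unknown.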